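The source may report more compounds than this note shows. Statements on the series, on what has been measured and on what is new or still open speak of the compounds shown alone.

Compound 1 `Cn1ncc2c1CCOC21CCN(N2CCC(c3ccccc3)CC2)CC1` gives 7 nM in an assay for displacement of a labelled ligand from Sigma non-opioid intracellular receptor 1 (Cavia porcellus), read by scintillation counting, with a stated time of 180 min; a lower number here means a stronger inhibitor, a higher number a weaker inhibitor. Compound 2 `COC1Cc2c(cnn2-c2ccccc2)C2(CCN(CCCCc3ccccc3)CC2)O1` gives 3.2 nM. Compound 3 `CCCN1CCC2(CC1)OC(OC)Cc1c2cnn1-c1ccccc1` gives 33 nM.

Compound 3 stands at the highest number of the three, that is, as the weakest inhibitor of the set: compound 1 sits nearest to it, and compound 2 sits furthest. Compound 4 `C=C(C)CCN1CCC2(CC1)OC(OC)Cc1c2cnn1-c1ccccc1` differs from compound 3 by a single change: 1-methylethenyl in place of methyl on a saturated chain carbon, two bonds along the chain from an amine nitrogen in a ring. For the measured compounds named here, the only measured step that bears on it is a 10-fold higher number from compound 2 to compound 3 (1.01 log units; beyond the scatter), where a benzyl group was taken away from the chain on the ring amine nitrogen and the number rose sharply. The change to compound 4 goes the other way: the chain grows again, though it gains a branched, open-chain group rather than a benzyl. On this basis a drop in the number is expected, of a size that stays well short of the step back to compound 2. For compound 4, the expected value in this assay is 15 nM, within a range from 5 nM to 45 nM, corresponding to an estimated step of a 2.2-fold lower number from compound 3 to compound 4 (0.34 log units; beyond the scatter).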

Compound 4, inhibition constant: 1.6 nM
For compound 4 the middle estimate is 9.4-fold (0.97 log units) above the measured one; the measured number lies below the stated range.
By their numbers in this assay, from the lowest: compounds 4 and 2 (each within the scatter of the next); then compound 1; then compound 3.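

Lengthening the chain on the ring amine nitrogen with 1-methylethenyl in place of methyl gives a 21-fold lower number from compound 3 to compound 4 (1.31 log units; beyond the scatter) in this assay and so shows that this position can respond strongly to a small open-chain group, not only to a group with a phenyl ring. The comparison with phenethyl at the same place gives a 2.0-fold lower number from compound 2 to compound 4 (0.30 log units; within the scatter) and is printed as within the scatter, so neither of these two compounds ranks above the other. Among these compounds, a phenyl ring at the end of the chain is therefore not required for a low number.

A saturated 3-methylbutyl chain and a straight butyl chain on the same nitrogen would help separate the roles of the double bond, the branch and the chain length. No measurement is available that explains the size of this step.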